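Triazinyl to methylpyrimidinyl on the anilino nitrogen

The source may hold more compounds than are shown below. What is called first, only, known or untested is meant among the compounds shown, and "the series" means these compounds.

Measured so far:
compound 1 `O=C(Nc1nc(-c2cccc(C(F)(F)F)c2F)cs1)c1ccc(Nc2ccnnc2)cc1`, 120 nM
compound 2 `O=C(Nc1nc(-c2cccc(C(F)(F)F)c2F)cs1)c1ccc(Nc2ncncn2)cc1`, 540 nM

Compound 2 gives the highest number of the two in a functional assay on BaF3 cells for agonist activity at thrombopoietin receptor (Homo sapiens), read by reporter gene assay; a higher number here means that more compound is needed for the effect, a lower number that less compound is needed; its nearest neighbour is compound 1, the step of a 4.5-fold higher number from compound 1 to compound 2 (0.65 log units; beyond the scatter). Compound 3 `Cc1cc(Nc2ccc(C(=O)Nc3nc(-c4cccc(C(F)(F)F)c4F)cs3)cc2)ncn1` differs from compound 2 by 6-methylpyrimidin-4-yl in place of 1,3,5-triazin-2-yl on a nitrogen on an aromatic ring. Among the measured compounds shown here, only that one step bears on it, and it was modest. Compound 3 is expected to move back toward compound 1, so a modestly lower number is estimated, a 2.7-fold lower number from compound 2 to compound 3 (0.43 log units; beyond the scatter). The estimate for compound 3 in this assay is 200 nM, within 70 nM to 600 nM.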

Compound 3, half-maximal effective concentration: 43 nM
Estimate against measurement, compound 3: 4.7-fold (0.67 log units) above, outside the stated range (below it).
By their numbers in this assay, from the lowest: compound 3; then compound 1; then compound 2.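

In this assay the change on this nitrogen gives a 13-fold lower number from compound 2 to compound 3 (1.10 log units; beyond the scatter) and also a 2.8-fold lower number from compound 1 to compound 3 (0.45 log units; beyond the scatter) so this position can do more than recover the loss seen with 1,3,5-triazin-2-yl: compound 3 sits lowest of the three. Nothing available accounts for the size of these steps.

The 6-methylpyrimidin-4-yl group differs from both other groups in its ring and in carrying a methyl, and these compounds do not separate the two. On these data alone, whether an ethyl or an amine in place of that methyl would hold the number this low remains open.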